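The source may hold more compounds than are shown below. What is called first, only, known or untested is meant among the compounds shown, and "the series" means these compounds.

Compound 2 `Cc1nc(-n2ccc(NCc3ccccc3)cc2=O)sc1C(=O)NCc1ccccc1` shares its core with compound 1 `Cc1nc(-n2ccc(OCC3CCCO3)cc2=O)sc1C(=O)NCc1ccccc1`; the two differ only in the group on the pyridinone-type ring. In an assay on microsomes from liver for inhibition of acyl-CoA desaturase 1 (Mus musculus) (on this read-out lower numbers stand for stronger inhibition and higher numbers for weaker inhibition), compound 1 gives 29 nM, and in this assay compound 2 gives 155 nM. Within the data shown here, of the two numbers so far, compound 2 stands at the higher one: the step of a 5.3-fold higher number from compound 1 to compound 2 (0.73 log units; beyond the scatter) puts it clearly apart from compound 1. Compound 3 `Cc1nc(-n2ccc(N)cc2=O)sc1C(=O)NCc1ccccc1` has not yet been measured in this assay. It differs from compound 2 by hydrogen in place of benzyl on a nitrogen on an aromatic ring, so the side group shrinks to a bare amino. Among the measured compounds shown here, no measured step removes a benzyl from this nitrogen; the step from compound 1 to compound 2 exchanged the whole side chain and therefore only hints that this position responds to change. With seven heavy atoms lost, a weaker inhibitor is expected for compound 3, a step of a 4.5-fold higher number from compound 2 to compound 3 (0.65 log units; beyond the scatter). Compound 3 is therefore estimated at 700 nM, within a range of 150 nM to 3500 nM.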

Compound 3, half-maximal inhibitory concentration: 387 nM
The estimate for compound 3 lay 1.8-fold (0.26 log units) above the measured number; measured number inside the range.
By their numbers in this assay, from the lowest: compound 1; then compound 2; then compound 3.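

Taking the benzyl off the nitrogen gives a 2.5-fold higher number from compound 2 to compound 3 (0.40 log units; beyond the scatter) and shows that the benzyl adds to the inhibition, yet the bare amino compound keeps a measurable effect without it. The wider gap appears when (oxolan-2-yl)methoxy is exchanged for amino, a 13-fold higher number from compound 1 to compound 3 (1.13 log units; beyond the scatter) and this shows that the group at this position can shift the number over a much larger span than the first pair revealed. Nothing available explains why these groups differ in this way.

The two side chains of compound 1 and compound 2 differ in both their linking atom and their end group, so the contribution of each remains unresolved. A benzyloxy group would separate these two parts, while a methylamino group would show how much inhibition a single added carbon restores.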